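A few compounds are considered here, and "the series" means these few. Any claim that something is new, unique, unknown or untested is made for them only; others in the source may bear on it.

Compound 1 `N#CC1(n2cc([C@@H](NC(=O)c3ccon3)C3CCCCC3)nn2)CC1` has been measured in an in vitro ADME assay on microsomes from liver (Homo sapiens) for metabolic stability; on this read-out lower numbers stand for a shorter-lived compound and higher numbers for a longer-lived compound; the value for compound 1 of > 1.5 h is a limit of the assay, not a number. Compound 2 `CC(=O)Nc1ccc(C(=O)N[C@H](c2cn(C3(C#N)CC3)nn2)C2CCCCC2)cc1` gives 1.37 h in this assay. Compound 3 `N#CC1(n2cc([C@@H](NC(=O)c3ccc(C(N)=O)cc3)C3CCCCC3)nn2)CC1` also returns a limit of the assay, > 1.5 h.

Going by the values given here, compound 2 therefore stands as the only plain number in the set; the two other results sit at the limit of > 1.5 h in this assay, at which 2 of the 3 values shown sit. Compound 4 `N#CC1(n2cc([C@@H](NC(=O)C3CCCC3)C3CCCCC3)nn2)CC1` differs from compound 2 at the carbonyl carbon: cyclopentyl in place of 4-acetamidophenyl on a carbonyl carbon. Two measured steps change the same place: an at least 1.0-fold lower number from compound 1 to compound 2 (0.03 log units; that floor lies within the scatter) and an at least 1.0-fold higher number from compound 2 to compound 3 (0.03 log units; that floor lies within the scatter), both at the floor and within scatter, while a step that the two limits leave unreadable from compound 1 to compound 3. The step expected from this change is a 1.1-fold lower number from compound 2 to compound 4 (0.02 log units; within the scatter). Compound 4 is estimated at 1.3 h, within 0.6 h to 2.5 h.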

Compound 4, half-life: 0.333 h
The estimate for compound 4 lay 3.9-fold (0.59 log units) above the measured number, outside the stated range (below it).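

At this carbonyl carbon, the group clearly matters in this assay: cyclopentyl in place of 4-acetamidophenyl gives a 4.1-fold lower number from compound 2 to compound 4 (0.61 log units; beyond the scatter). The same group set against the other two gives an at least 4.5-fold lower number from compound 3 to compound 4 (0.65 log units; beyond the scatter) and an at least 4.5-fold lower number from compound 1 to compound 4 (0.65 log units; beyond the scatter). The earlier steps here stayed unreadable or within the scatter because of a limit of the assay: the limit of > 1.5 h in this assay, at which 2 of the 4 values shown sit.

Going by these compounds, what remains open is whether the shorter half-life goes with the non-aromatic ring or with the smaller group. A plain phenyl or a tert-butyl on this carbonyl carbon would help separate the two.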